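The source may report more compounds than this note shows. Statements on the series, on what has been measured and on what is new or still open speak of the compounds shown alone.

Values in an ADME assay on Vero cells (Chlorocebus sabaeus) for cytotoxicity, read by resazurin assay, with a stated time of 72 h (a higher number here means a weaker inhibitor, a lower number a stronger inhibitor), for the series:
compound 1 `O=C(CCN1CCN(c2ccc(C(F)(F)F)cc2)CC1)c1ccc(Br)cc1` gives 78800 nM
compound 2 `O=C(CCN1CCN(c2ccc(Cl)cc2)CC1)c1ccc(Br)cc1` gives 52100 nM
compound 3 `O=C(CCN1CCN(c2ccc([N+](=O)[O-])cc2)CC1)c1ccc(Br)cc1` gives 79800 nM

Compound 2 does not separate from compound 1 or compound 3: the steps (a 1.5-fold lower number from compound 1 to compound 2 (0.18 log units; within the scatter)) and (a 1.5-fold higher number from compound 2 to compound 3 (0.19 log units; within the scatter)) stay within the scatter, as does the remaining one (a 1.0-fold higher number from compound 1 to compound 3 (0.01 log units; within the scatter)). Still to be measured is compound 4 `O=C(CCN1CCN(c2ccc(Cl)cc2)CC1)c1ccc(F)c(Br)c1` with the change (3-bromo-4-fluorophenyl in place of 4-bromophenyl on a carbonyl carbon), 3-bromo-4-fluorophenyl in place of 4-bromophenyl on a carbonyl carbon. Among the measured compounds shown here, no measured step touches the 4-bromophenyl. The three steps exchange trifluoromethyl, chloro and nitro on an aromatic carbon, so they bear on this change only indirectly. No step beyond the scatter is therefore expected in this assay for this change. The expected step is small (a 1.0-fold lower number from compound 2 to compound 4 (0.02 log units; within the scatter)) and stays close to compound 2. For compound 4 the estimated value is 50000 nM with an expected range from 25000 nM to 100000 nM in this read-out.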

Compound 4, half-maximal inhibitory concentration: 206000 nM
The estimate for compound 4 lay 4.1-fold (0.61 log units) below the measured number, outside the stated range (above it).
By their numbers in this assay, from the lowest: compounds 2, 1 and 3 (each within the scatter of the next); then compound 4.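

In this assay, among the compounds shown here, changing the aryl group on the carbonyl carbon gives a 4.0-fold higher number from compound 2 to compound 4 (0.60 log units; beyond the scatter), the only step beyond the scatter; the exchanges among trifluoromethyl, chloro and nitro all stayed within it. This position therefore affects the read-out, and the higher number comes with 3-bromo-4-fluorophenyl in place of 4-bromophenyl. Nothing available accounts for this step.

The compounds shown do not separate the added fluorine from the changed bromine place. On these data alone, how an amine or a carboxylic acid on this aromatic ring would read also remains open.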